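Vinyl in place of prop-1-en-1-yl on two carbonyls

This account rests on a few compounds, and the source may have more. Where it says the series, first, only, none or still open, it means among the compounds named here.

Compound 1, `C=CC(=O)Nc1ccc(Cn2nc(-c3ccc(Oc4ccccc4)cc3)cc2C(=O)OCC)cc1`: 10900 nM
Compound 2, `C/C=C/C(=O)Nc1ccc(Cn2nc(-c3ccc(Oc4ccccc4)cc3)cc2C(=O)OCC)cc1`: 52500 nM
Compound 3, `C/C=C/C(=O)N1CCCC(n2nc(-c3ccc(Oc4ccccc4)cc3)cc2CO)C1`: > 60000 nM

Of the compounds shown here, three have been measured in a functional assay on JeKo-1 cells (Homo sapiens) for inhibition, read by luminescence and CellTiter-Glo, with a stated time of 72 h; a lower number here means a stronger inhibitor, a higher number a weaker inhibitor. Compound 1 gives 10900 nM and compound 2 gives 52500 nM in this assay. For compound 3 this assay reports only a limit, > 60000 nM, and the same holds for (the limit of > 60000 nM in this assay, at which 1 of the 3 values shown sits). Compound 2 becomes compound 1 by vinyl in place of prop-1-en-1-yl on a carbonyl carbon, and that step reads a 4.8-fold lower number from compound 2 to compound 1 (0.68 log units; beyond the scatter). Compound 4, `C=CC(=O)N1CCCC(n2nc(-c3ccc(Oc4ccccc4)cc3)cc2CO)C1`, has not yet been measured in this assay; it differs from compound 3 by vinyl in place of prop-1-en-1-yl on a carbonyl carbon. The place is not identical in the two pairs: in compound 2 the carbonyl carbon's other neighbour is an amide-type nitrogen, in compound 3 an amide-type nitrogen in a ring, so this is the same kind of change, not the same change. The difference between the core of compound 2 and the core of compound 3 is not broken down here. Compound 4 is expected to give 25000 nM, between 6000 nM and 60000 nM, because compound 1 and compound 2 show a 4.8-fold lower number from compound 2 to compound 1 (0.68 log units; beyond the scatter) for this kind of change, while compound 3 itself has only a limit. That estimate means a step of an at least 2.4-fold lower number from compound 3 to compound 4 (0.38 log units; beyond the scatter), and it is only an expectation.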

Compound 4, half-maximal inhibitory concentration: 11900 nM
Compound 4: the middle estimate sits 2.1-fold (0.32 log units) above what was measured; low and high end bracket the measured number.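

In this assay, vinyl in place of prop-1-en-1-yl on a carbonyl carbon again goes with a lower number, an at least 5.0-fold lower number from compound 3 to compound 4 (0.70 log units; beyond the scatter), so the direction of the change seen on the core of compound 2 also appears on the core of compound 3, where the carbonyl carbon's other neighbour is an amide-type nitrogen in a ring. Set side by side, the two steps read: the same change on two cores in this assay, a 4.8-fold lower number (0.68 log units; beyond the scatter) from compound 2 to compound 1 and an at least 5.0-fold lower number (0.70 log units; beyond the scatter) from compound 3 to compound 4; the limit leaves it open whether they differ. Compound 3 has only a limit, > 60000 nM, and this pair of cores therefore shows a shared direction but neither that the size of the change carries over nor that it would hold on any further core.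

The compounds shown leave open whether a chain carrying an amine or a propynoyl group with its alkyne on the carbonyl carbon would follow the same direction in this assay. On these data alone, it also remains open how a carboxylic acid in place of the ethyl ester of compound 1 would read there.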